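Ether side chains: from compound 2 to compound 3

This account rests on a few compounds, and the source may have more. Where it says the series, first, only, none or still open, it means among the compounds named here.

- compound 1 `CCCCCCOC[C@@H]1C2CCC(O2)[C@@H]1C/C=C\CCCC(=O)O` gives 38500 nM; 10000 nM (2 entries)
- compound 2 `CCC/C=C\COCC1C2CCC(O2)C1C/C=C\CCCC(=O)O` gives 3300 nM

For the measured compounds named here, in a functional assay (plasma) for inhibition, with Homo sapiens as the target (a higher number here means a weaker inhibitor, a lower number a stronger inhibitor), compound 2 gives the only single number (3300 nM), whereas compound 1 has two entries that lie well apart (the several entries of compound 1 in this assay, 38500 nM; 10000 nM (2 entries)). Compound 3 `CCCCCOCCC1C2CCC(O2)C1C/C=C\CCCC(=O)O` carries one change from compound 2 (a group of 7 heavy atoms (6 carbon, 1 oxygen; no ring) in place of a group of 7 heavy atoms (6 carbon, 1 oxygen; no ring), on a saturated chain carbon bound to a saturated ring carbon). Going by the values given here, no step between measured compounds covers this change. Compound 1 (38500 nM; 10000 nM (2 entries)) also lacks a double bond in this side chain and both its entries stand higher than that of compound 2, so somewhat weaker inhibition is expected. The estimated change a 2.1-fold higher number from compound 2 to compound 3 (0.33 log units; beyond the scatter) is modest. For compound 3 the estimated value is 7000 nM (expected range 2000 nM to 25000 nM).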

Compound 3, half-maximal inhibitory concentration: 105000 nM
For compound 3 the middle estimate is 15-fold (1.18 log units) below the measured one; measured number above the stated range.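

In this assay this change gives a 32-fold higher number from compound 2 to compound 3 (1.50 log units; beyond the scatter), although the heavy-atom count, the absence of a ring and the donor and acceptor counts all stay the same. The double bond present in the group that leaves is absent from (pentyloxy)methyl, but the atoms of the chain are also arranged differently, so the step cannot be assigned to either difference alone. Inhibition is therefore sensitive to the makeup of this side chain, even at equal heavy-atom count.

On these data alone, how a longer chain or an amine in this side chain would read remains open. Compound 1 offers no firm reference point, given its spread: the several entries of compound 1 in this assay, 38500 nM; 10000 nM (2 entries)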